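The compounds below may be only part of what the source reports. "The series", "measured", "known", "first", "only" and "open" are said of these compounds alone.

Measured in an ADME assay on MT4 cells (Homo sapiens) for cytotoxicity, read by MTT assay; a higher number here means that more compound is tolerated, a lower number that less compound is tolerated:
Compound 1 `Cc1cc(C)cc(S(=O)(=O)c2c(C(=O)NCc3cccc(F)c3)[nH]c3ccc(Cl)cc23)c1`: > 53000 nM (a limit)
Compound 2 `Cc1cc(C)cc(S(=O)(=O)c2c(C(=O)NCc3ccc(N(C)C)cc3)[nH]c3ccc(Cl)cc23)c1`: 40700 nM

Among the measured compounds shown here, compound 2, at 40700 nM, holds the only actual number in this assay so far. Compound 1 gives > 53000 nM, which is a limit of the assay and not a number. Compound 3 `Cc1cc(C)cc(CNC(=O)c2[nH]c3ccc(Cl)cc3c2S(=O)(=O)c2cc(C)cc(C)c2)c1` is still unmeasured. It keeps the core of compound 2 and carries 3,5-dimethylphenyl in place of 4-(dimethylamino)phenyl on a saturated chain carbon bound to an amide-type nitrogen.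

For the measured compounds named here, one measured step bears on this change, since it alters the group at the same place: an at least 1.3-fold lower number from compound 1 to compound 2 (0.11 log units; that floor lies within the scatter). That step shows no change beyond the scatter, so no step beyond the scatter is expected here, and no direction can be called. The expected change is a 1.1-fold higher number from compound 2 to compound 3 (0.04 log units; within the scatter). Compound 3 is estimated at 45000 nM, with an expected range from 22000 nM to 90000 nM.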

Compound 3, half-maximal cytotoxic concentration: > 51900 nM
Compound 3 was reported as a limit; the forecaster's own chance of this, stated with the estimate: 50%; at least 1.1-fold (0.06 log units) between middle value and limit.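

In this assay the result for compound 3 is a limit of the assay and not a number: the limit of > 51900 nM in this assay, at which 1 of the 3 values shown sits. Set against the one actual number in the series, the change from 4-(dimethylamino)phenyl to 3,5-dimethylphenyl gives an at least 1.2-fold higher number from compound 2 to compound 3 (0.10 log units; that floor lies within the scatter), so this second change at the position again shows nothing beyond the scatter, while its true size stays unknown. Compound 3 now joins compound 1 in ending at a limit, and the step between these two compounds cannot be read.

The compounds shown leave open how large the step from compound 2 to compound 3 really is. They also leave open whether a carboxylic acid or a morpholine at this place, on a saturated chain carbon bound to an amide-type nitrogen, would give a number clearly apart from that of compound 2.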